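This account rests on a few compounds, and the source may have more. Where it says the series, first, only, none or still open, it means among the compounds named here.

The three measured compounds and their numbers:

compound 1, `CCC1=C(O)c2c(oc(-c3ccc(OC)cc3)cc2=O)C(CC)(CC)C1=O`, gives 0.68 uM in a functional assay on KBVIN cells (Homo sapiens) for antiproliferative activity, read by sulforhodamine B assay, with a stated time of 3 days; on this read-out lower numbers stand for an effect already at smaller amounts and higher numbers for an effect only at larger amounts of compound
compound 2, `CCC1=C(O)c2c(oc(-c3cccc(OC)c3)cc2=O)C(CC)(CC)C1=O`, gives 1.22 uM
compound 3, `CCC1=C(O)c2c(oc(-c3ccccc3C)cc2=O)C(CC)(CC)C1=O`, gives 2.41 uM

Compound 3 carries the highest of the three numbers. Its nearest neighbour is compound 2, the step of a 2.0-fold higher number from compound 2 to compound 3 (0.30 log units; within the scatter) lying within the scatter, and its furthest is compound 1, from which the step of a 3.5-fold higher number from compound 1 to compound 3 (0.55 log units; beyond the scatter) is beyond the scatter and modest in size. The two methoxyphenyl compounds themselves are separated only by a 1.8-fold higher number from compound 1 to compound 2 (0.25 log units; within the scatter), which is within the scatter.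

Compound 4, `CCC1=C(O)c2c(oc(-c3cc(C)c(O)c(C)c3)cc2=O)C(CC)(CC)C1=O`, is obtained from compound 3 by the change (4-hydroxy-3,5-dimethylphenyl in place of 2-methylphenyl on an aromatic carbon). Among the compounds with values here, no measured step exchanges a methylphenyl for a hydroxy-dimethylphenyl, so the only guide is that the aryl group on the shared core moves the number over a modest span at most, as the step of a 3.5-fold higher number from compound 1 to compound 3 (0.55 log units; beyond the scatter) shows, and that the 2-methylphenyl of compound 3 sits at the high end of that span. A step back toward the lower numbers is therefore expected, of modest size, a 2.0-fold lower number from compound 3 to compound 4 (0.30 log units; within the scatter), with the caveat that it may also stay within the scatter.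

For compound 4 the estimated value in this assay is 1.2 uM, with an expected range from 0.4 uM to 4 uM.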

Compound 4, concentration for half-maximal effect: 8.9 uM
For compound 4 the middle estimate is 7.4-fold (0.87 log units) below the measured one, outside the stated range (above it).
By their numbers in this assay, from the lowest: compounds 1, 2 and 3 (each within the scatter of the next, the first and the last beyond it); then compound 4.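

In this assay, the 4-hydroxy-3,5-dimethylphenyl group takes the number out of the narrow span set by the earlier aryl groups: a 3.7-fold higher number from compound 3 to compound 4 (0.57 log units; beyond the scatter) is a modest step beyond the scatter, a 7.3-fold higher number from compound 2 to compound 4 (0.86 log units; beyond the scatter) is also modest, and a 13-fold higher number from compound 1 to compound 4 (1.12 log units; beyond the scatter) is large. Until now, exchanging the aryl group on this aromatic carbon next to the ring oxygen had produced at most a modest step, so the result shows that this position can respond more strongly than compounds 1, 2 and 3 suggested, with compound 4 above all three of them. Nothing available explains this rise.

The entering group adds a hydroxy group and two methyl groups at once, so the compounds shown leave open whether a phenyl ring carrying the hydroxy group alone, or the two methyl groups alone, would account for the higher number. They also leave open how the number would move with an amine or a carboxylic acid in place of that hydroxy group on the same ring.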